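Side-chain variation on the shared core: carbamoyl replaces diol

The compounds below may be only part of what the source reports. "The series", "measured", "known", "first", "only" and "open" are said of these compounds alone.

Three compounds share one core and differ only in the chain on the saturated ring carbon. Compound 1 `Cn1ncc(Cl)c1-c1cc(C(=O)N[C@@H]2CN[C@H](CC(=O)O)C[C@H]2c2ccc(Cl)c(Cl)c2)oc1Cl` carries a carboxy group there and in an assay for inhibition of RAC-alpha serine/threonine-protein kinase (Homo sapiens), read by HTRF, with a stated time of 1 h (on this read-out lower numbers stand for stronger inhibition and higher numbers for weaker inhibition), gives 1.94 nM. Compound 2 `Cn1ncc(Cl)c1-c1cc(C(=O)N[C@@H]2CN[C@H](CC(=O)NCC(O)CO)C[C@H]2c2ccc(Cl)c(Cl)c2)oc1Cl` carries a (2,3-dihydroxypropyl)carbamoyl and gives 3.13 nM. Compound 3 `Cn1ncc(Cl)c1-c1cc(C(=O)N[C@@H]2CN[C@H](CC(O)CO)C[C@H]2c2ccc(Cl)c(Cl)c2)oc1Cl` carries a 1,2-dihydroxyethyl and gives 3.79 nM. Compound 3 thus has the highest of the three numbers, but a 1.2-fold higher number from compound 2 to compound 3 (0.08 log units; within the scatter) and a 2.0-fold higher number from compound 1 to compound 3 (0.29 log units; within the scatter) both lie within the scatter, so no ordering of the three can be claimed; the whole series sits in a narrow band.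

Compound 4 `Cn1ncc(Cl)c1-c1cc(C(=O)N[C@@H]2CN[C@H](CC(=O)NCCO)C[C@H]2c2ccc(Cl)c(Cl)c2)oc1Cl` has not been measured. (2-hydroxyethyl)carbamoyl in place of 1,2-dihydroxyethyl on a saturated chain carbon bound to a saturated ring carbon The change resembles the reverse of the measured step, a 1.2-fold higher number from compound 2 to compound 3 (0.08 log units; within the scatter), since compound 4 carries a carbamoyl as compound 2 does. The step of a 1.6-fold higher number from compound 1 to compound 2 (0.21 log units; within the scatter) also shows that a carbamoyl in place of carboxy on this chain changes little. Compound 4 is therefore expected to land close to compound 2, with a 1.3-fold lower number from compound 3 to compound 4 (0.10 log units; within the scatter) and nothing beyond the scatter. Compound 4 is estimated at 3 nM, in a range from 1.5 nM to 6 nM.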

Compound 4, half-maximal inhibitory concentration: 1.41 nM
The estimate for compound 4 lay 2.1-fold (0.33 log units) above the measured number; measured number below the stated range.
By their numbers in this assay, from the lowest: compounds 4, 1, 2 and 3 (each within the scatter of the next, the first and the last beyond it).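

In this assay, among these compounds, the chain on the saturated ring carbon no longer looks indifferent: a 2.7-fold lower number from compound 3 to compound 4 (0.43 log units; beyond the scatter) and a 2.2-fold lower number from compound 2 to compound 4 (0.35 log units; beyond the scatter) are the first steps beyond the scatter, both modest, whereas every earlier step lay within it. The second of these is only hydrogen in place of hydroxymethyl within the carbamoyl chain, so even this small trim registers in the read-out, while the swap of (2-hydroxyethyl)carbamoyl for 1,2-dihydroxyethyl registers to a similar degree. By contrast, a 1.4-fold lower number from compound 1 to compound 4 (0.14 log units; within the scatter) stays within the scatter, so the (2-hydroxyethyl)carbamoyl chain and the carboxy group cannot be told apart here, and no supporting data offer a reason for any of these differences.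

Still open, from the compounds shown here alone, is whether the carbamoyl or its hydroxy carries the difference: an unsubstituted carbamoyl, a (2-methoxyethyl)carbamoyl or a longer chain such as (3-hydroxypropyl)carbamoyl on the same carbon would separate these. Going by these compounds, whether an amine in place of the carboxy group would stay in the same band also remains unknown.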